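A Methyl on the Ring Carbon of Compound 3

This account rests on a few compounds, and the source may have more. Where it says the series, first, only, none or still open, it means among the compounds named here.

Among the compounds with values here, compound 3 `O=C(NC1CCCCC1)Oc1cccc(C2=NCCO2)c1` gives the lowest number of the three compounds measured so far: in an assay (strain Wistar) for inhibition of Fatty-acid amide hydrolase 1 (Rattus norvegicus), read by scintillation counting (on this read-out higher numbers stand for weaker inhibition and lower numbers for stronger inhibition), compound 3 gives 1.2 nM. Compound 2 `O=C(NC1CCCC1)Oc1cccc(C2=NCCO2)c1` gives 13 nM in this assay, and compound 1 `CCCNC(=O)Oc1cccc(-c2nc3ccccc3o2)c1`, built on a different core, gives 3000 nM in this assay. Within the data shown here, the single step between compounds that differ in one place is an 11-fold lower number from compound 2 to compound 3 (1.03 log units; beyond the scatter), a large drop. Compound 4 `C[C@@H]1COC(c2cccc(OC(=O)NC3CCCCC3)c2)=N1` differs from compound 3 by methyl in place of hydrogen on a saturated ring carbon. Among the measured compounds shown here, no measured step touches that change: the only step, an 11-fold lower number from compound 2 to compound 3 (1.03 log units; beyond the scatter), concerns the ring on the amide-type nitrogen and not the five-membered ring, so nothing in the data points either way. With no direction to lean on, a step of no size beyond the scatter is expected in this assay, and the estimate amounts to a 1.3-fold higher number from compound 3 to compound 4 (0.10 log units; within the scatter). Compound 4 is therefore expected to give about 1.5 nM in this assay, with a range from 0.4 nM to 6 nM.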

Compound 4, half-maximal inhibitory concentration: 16 nM
Compound 4: middle estimate off by 11-fold (1.03 log units), on the low side; the whole stated range lies below it.
By their numbers in this assay, from the lowest: compound 3; then compounds 2 and 4 (each within the scatter of the next); then compound 1.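

In this assay, the saturated ring carbon next to the ring nitrogen proves sensitive to change: methyl in place of hydrogen gives a 13-fold higher number from compound 3 to compound 4 (1.12 log units; beyond the scatter), a large step toward weaker inhibition. Within the data shown here, the earlier step concerned only the ring on the amide-type nitrogen, so this is the first sign that the five-membered ring also moves the number, and that a single added carbon there is enough to do so. No measurement shown here accounts for this rise.

The compounds shown leave open whether an ethyl or a hydroxymethyl on this ring carbon, or the methyl in the opposite configuration, would give a similar number. They also leave open whether the same methyl would cost as much alongside the cyclopentyl group of compound 2.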